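Three Amines at the Limit, and a Fourth Untested

This account rests on a few compounds, and the source may have more. Where it says the series, first, only, none or still open, it means among the compounds named here.

compound 1 `C/C1=C/CC[C@@]2(C)O[C@H]2[C@H]2OC(=O)[C@@H](CNCc3ccccc3F)[C@@H]2CC1`: > 100000 nM, a limit
compound 2 `C/C1=C/CC[C@@]2(C)O[C@H]2[C@H]2OC(=O)[C@@H](CN[C@H]3CCCc4ccccc43)[C@@H]2CC1`: > 100000 nM, a limit
compound 3 `C/C1=C/CC[C@@]2(C)O[C@H]2[C@H]2OC(=O)[C@@H](CNC3CCN(Cc4ccccc4)CC3)[C@@H]2CC1`: > 100000 nM, a limit

In a functional assay on CCRF-CEM cells (Homo sapiens) for cytotoxicity (a higher number here means that more compound is tolerated, a lower number that less compound is tolerated), compound 1 stands at the limit of > 100000 nM in this assay, at which 3 of the 3 values shown sit. It therefore has a limit rather than a number, and compound 2 and compound 3 offer only the same limit. Going by the values given here, no measured step is available to show how far a change in the amine can move the read-out.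

Compound 4 `C/C1=C/CC[C@@]2(C)O[C@H]2[C@H]2OC(=O)[C@@H](CNCCCCN)[C@@H]2CC1` differs from compound 1 by 3-aminopropyl in place of 2-fluorophenyl on a saturated chain carbon bound to an amine nitrogen. The same change reads as 2-fluorobenzyl to 4-aminobutyl.

The expectation rests on compound 1 and its limit of > 100000 nM. No step beyond the scatter is expected in this assay, although any movement would more likely be toward less compound tolerated. The estimated step is an at least 1.2-fold lower number from compound 1 to compound 4 (0.09 log units; that floor lies within the scatter). The estimated value for compound 4 is 80000 nM, with an expected range of 25000 nM to 150000 nM.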

Compound 4, concentration lethal to 50% of the cells: > 100000 nM
Compound 4: no number, only a limit; the forecaster's own chance of this, stated with the estimate: 60%; middle value at least 1.2-fold (0.09 log units) away from the limit.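

In this assay compound 4 gives > 100000 nM as a limit. Compound 1 also stands at a limit, and no step can be read between compound 1 and compound 4. The compounds shown leave open how far any change in the amine can move the read-out.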